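Swapping the chain end of compound 3 for a tetrazole

The compounds below may be only part of what the source reports. "The series", "measured", "known", "first", "only" and "open" are said of these compounds alone.

Values in a physicochemical assay for solubility, in phosphate buffer, measured as thermodynamic solubility, at pH 7.4; a higher number here means a more soluble compound, a lower number a less soluble compound
Compound 1 (`CS(=O)(=O)NC(=O)CCc1cn(C2CCCCC2)nc1-c1ccc(Cl)cc1`) gives 200000 nM
Compound 2 (`CS(=O)(=O)NC(=O)CCc1cn(-c2ccc(C#N)cc2)nc1-c1ccc(Cl)cc1`) gives 75000 nM
Compound 3 (`CN(C(=O)CCc1cn(-c2ccc(Br)cc2)nc1-c1ccc(Cl)cc1)S(C)(=O)=O`) gives < 5000 nM as a limit of the assay, not a number

For compound 3 the assay reports only a limit (< 5000 nM). Compound 4 (`Clc1ccc(-c2nn(-c3ccc(Br)cc3)cc2CCc2nnn[nH]2)cc1`) carries 1H-tetrazol-5-yl in place of methyl(methylsulfonyl)carbamoyl on a saturated chain carbon, two bonds along the chain from an aromatic carbon. Within the data shown here, no measured step covers this change. Among the measured compounds shown here, the one measured step (a 2.7-fold lower number from compound 1 to compound 2 (0.43 log units; beyond the scatter)) concerns the group on an aromatic nitrogen, so it bears only indirectly and is modest. With a 4-cyanophenyl group there, compound 2 still gives a number (75000 nM). On that ground, a sizeable step to a higher number is expected in this assay (an at least 8.0-fold higher number from compound 3 to compound 4 (0.90 log units; beyond the scatter)). For compound 4 the expected value is 40000 nM (estimated range 8000 nM to 150000 nM).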

Compound 4, solubility: 150000 nM
For compound 4 the middle estimate is 3.8-fold (0.57 log units) below the measured one, within the range that was stated.
By their numbers in this assay, from the lowest: compounds 2, 4 and 1 (each within the scatter of the next, the first and the last beyond it). At a limit, below all of these: compound 3.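

In this assay compound 3 gives < 5000 nM, which is a limit of the assay and not a number. The earlier step concerned only the group on an aromatic nitrogen, whereas at the chain end 1H-tetrazol-5-yl in place of methyl(methylsulfonyl)carbamoyl gives an at least 30-fold higher number from compound 3 to compound 4 (1.47 log units; beyond the scatter). The true size of this large change therefore remains unknown, and it rests on a floor: the limit of < 5000 nM in this assay, at which 1 of the 4 values shown sits.

From the compounds shown here alone, how a carboxylic acid in place of 1H-tetrazol-5-yl would read at this position stays open. So does whether a longer chain carrying the tetrazole would read the same.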